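Methyl to Fluorine on the Outer Phenyl Ring

A few compounds are considered here, and "the series" means these few. Any claim that something is new, unique, unknown or untested is made for them only; others in the source may bear on it.

In a functional assay on HepG2 cells (Homo sapiens) for antiproliferative activity, read by MTT assay, with a stated time of 24 h (on this read-out higher numbers stand for weaker inhibition and lower numbers for stronger inhibition), compound 2 `Cc1ccc(-n2cc(-c3ccccc3NS(=O)(=O)c3c[nH]c(=O)[nH]c3=O)nn2)cc1` gives 8350 nM, the lowest of the two numbers, while compound 1 `Cc1ccccc1-n1cc(-c2ccccc2NS(=O)(=O)c2c[nH]c(=O)[nH]c2=O)nn1` gives 13900 nM, within the scatter of it. Compound 3 `O=c1[nH]cc(S(=O)(=O)Nc2ccccc2-c2cn(-c3cccc(F)c3)nn2)c(=O)[nH]1` carries the change (3-fluorophenyl in place of 4-methylphenyl on an aromatic nitrogen). Among the measured compounds shown here, the only measured step, a 1.7-fold lower number from compound 1 to compound 2 (0.22 log units; within the scatter), altered the same phenyl ring without moving beyond the scatter, and it offers no direct guide to trading methyl for fluorine. No shift beyond the scatter is therefore expected, and the step of a 1.0-fold higher number from compound 2 to compound 3 (0.01 log units; within the scatter) expresses this. Compound 3 is estimated at 8500 nM, within the range 3000 nM to 25000 nM.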

Compound 3, half-maximal inhibitory concentration: > 20000 nM
Compound 3: no number, only a limit; the forecaster's own chance of this, stated with the estimate: 5%; at least 2.3-fold (0.37 log units) between middle value and limit.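

Compound 3 gives no number in this assay, only a limit: the limit of > 20000 nM in this assay, at which 1 of the 3 values shown sits. Even so, replacing 4-methylphenyl with 3-fluorophenyl on the aromatic nitrogen gives an at least 2.3-fold higher number from compound 2 to compound 3 (0.37 log units; beyond the scatter), so this position does respond to the group it carries, which the methyl shift alone had not shown. Replacing 2-methylphenyl with 3-fluorophenyl tells less, giving an at least 1.4-fold higher number from compound 1 to compound 3 (0.15 log units; that floor lies within the scatter), and no order can be drawn from it.

This change swaps the group and also its place on the phenyl ring, and the compounds shown cannot separate these two effects. On these data alone, how an amine or a methoxy group on this ring would behave remains open.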